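A few compounds are considered here, and "the series" means these few. Any claim that something is new, unique, unknown or untested is made for them only; others in the source may bear on it.

Measured so far in an ADME assay on cells (Macrophage, Mus musculus) for cytotoxicity, read by LDH release, with a stated time of 48 h; a higher number here means a weaker inhibitor, a lower number a stronger inhibitor:
Compound 1 `CC[C@H](C)[C@H]1O[C@]2(CC[C@@H]1C)C[C@@H](O)C[C@@H](CCO)O2`: > 90000 nM (a limit of the assay, not a number)
Compound 2 `CC[C@H](C)[C@H]1O[C@]2(CC[C@@H]1C)C[C@@H](O)C[C@@H](C/C=C(\C)[C@@H](O[C@H]1C[C@H](OC)[C@@H](O)[C@H](C)O1)[C@@H](C)CO)O2`: 32100 nM

For the measured compounds named here, compound 2 gives the only actual number in this assay, at 32100 nM. Compound 1 gives only a limit, > 90000 nM. The two readings therefore fix no exact gap, and compound 2 has no measured close neighbour to set it against.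

Compound 3 `CC[C@H](C)[C@H]1O[C@]2(CC[C@@H]1C)C[C@@H](O)C[C@@H](C/C=C(\C)[C@@H](O)[C@@H](C)CO)O2` derives from compound 2 by a single change, (hydrogen in place of 5-hydroxy-4-methoxy-6-methyloxan-2-yl on an oxygen on a saturated carbon). The oxygen on a saturated carbon keeps a hydrogen in place of 5-hydroxy-4-methoxy-6-methyloxan-2-yl. Going by the values given here, no measured pair shows what this change does, so any forecast is loose. Since compound 2 reads 32100 nM, close to the top of the measurable range, there is little room for a large rise, and a modest move towards weaker inhibition is expected. The reading could also stop at the limit of this assay. The expected size of the change is a 1.9-fold higher number from compound 2 to compound 3 (0.27 log units; within the scatter). For compound 3 the estimated value is 60000 nM, with an expected range from 30000 nM to 90000 nM.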

Compound 3, half-maximal inhibitory concentration: > 90000 nM
Compound 3 was reported as a limit; the forecaster's own chance of this, stated with the estimate: 45%; middle value at least 1.5-fold (0.17 log units) from the limit.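

In this assay, replacing the 5-hydroxy-4-methoxy-6-methyloxan-2-yl group on this oxygen with hydrogen gives an at least 2.8-fold higher number from compound 2 to compound 3 (0.44 log units; beyond the scatter). For the compounds shown here, this is the first measured step, and it shows that the change at this oxygen on a saturated carbon moves the reading towards weaker inhibition by more than the usual scatter. Among the compounds shown, only compound 2, which carries this group, gives a number in this assay, and the full size of the step remains unknown because the reading for compound 3 stops at a limit of the assay: the limit of > 90000 nM in this assay, at which 2 of the 3 values shown sit.

The step from compound 1 to compound 3 cannot be read, as both readings are limits, so the compounds shown do not tell whether the longer chain of compound 3 alters the reading at all. On these data alone, it also remains open whether a smaller group on the same oxygen, such as a methyl or an acetyl group, would give a number in this assay or whether the whole 5-hydroxy-4-methoxy-6-methyloxan-2-yl group is needed.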